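The compounds below may be only part of what the source reports. "The series", "measured", "known", "first", "only" and "open" are said of these compounds alone.

Measured so far in an ADME assay on microsomes from liver (Mus musculus) for metabolic stability, read by LC-MS, with NADPH named in the record, with a stated time of 60 min, tested at 1 uM, in the absence of a further agent; on this read-out lower numbers stand for a less stable compound and higher numbers for a more stable compound:

Compound 1, `COc1ccc(-n2c(C)nc3c(N4CC[C@@H](NC(C)=O)C4)nc(C)nc32)cc1OC`, gives > 95% in this assay, a value that is a limit of the assay and not a number.
Compound 2, `COc1ccc(-c2scc3c(N4CC[C@@H](NC(C)=O)C4)nc(C)nc23)cc1OC`, gives > 95%, again a limit of the assay.
Compound 3, `COc1ccc(-c2c(C)nc3c(N4CC[C@@H](NC(=O)NC(C)C)C4)cc(C)nn23)cc1OC`, gives > 95%, also a limit of the assay.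

Where compound 3 stands is therefore known only as a boundary: the limit of > 95% in this assay, at which 3 of the 3 values shown sit. Among the compounds with values here, no two of the measured compounds differ in a single place, so no measured step in this assay can be quoted, and the three values, all at the limit, allow no ranking among them.

The next compound, compound 4, `COc1ccc(-c2c(C)nc3c(N4CC[C@@H](NS(N)(=O)=O)C4)cc(C)nn23)cc1OC`, is reached from compound 3 by one change: sulfamoyl in place of isopropylcarbamoyl on an amine nitrogen.

Within the data shown here, no measured step of this kind exists, so the size of the expected step rests on the standing of compound 3 at the limit alone. The working expectation is a step from compound 3 to compound 4 that stays within the usual scatter of this assay, with the remaining uncertainty leaning downward rather than upward, since compound 3 can only be exceeded in the direction of a lower number. For compound 4 the estimate is 92%, within 78% to 99%, corresponding to an expected step of a number at least 3 percentage points lower from compound 3 to compound 4 (that floor lies within the scatter).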

Compound 4, percent of the compound remaining: > 95%
Compound 4 gave a limit, no number; the forecaster's own chance of this, stated with the estimate: 55%; middle value at least 3 percentage points from the limit.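

In this assay compound 4 gives > 95%, a limit of the assay and not a number. Compound 3 also stands at a limit, so no step can be read between compound 3 and compound 4. The compounds shown leave open any ranking among them, all resting at one boundary: the limit of > 95% in this assay, at which 4 of the 4 values shown sit.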